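The compounds below may be only part of what the source reports. "The series", "measured", "known", "first", "only" and "open" are said of these compounds alone.

The measured compounds in an ADME assay on T29 cells (Homo sapiens) for cytotoxicity, read by sulforhodamine B assay, with a stated time of 3 days; a lower number here means a stronger inhibitor, a higher number a weaker inhibitor:
compound 1, `OCc1cn(Cc2ccccc2)c2ccccc12`, gives 14500 nM.
compound 2, `OCc1cn(Cc2cccc(C(F)(F)F)c2)c2ccccc12`, gives > 31600 nM, which is a limit of the assay and not a number.
compound 3, `Cc1cccc(Cn2cc(CO)c3ccccc32)c1`, gives > 31600 nM, again a limit of the assay and not a number.

Compound 3 therefore stands at the limit rather than at a measured number, and it does so together with one other compound (the limit of > 31600 nM in this assay, at which 2 of the 3 values shown sit). Compound 4, `O=[N+]([O-])c1cccc(Cn2cc(CO)c3ccccc32)c1`, differs from compound 3 by nitro in place of methyl on an aromatic carbon. Within the data shown here, two measured steps bear on a substituent entering this ring: an at least 2.1-fold higher number from compound 1 to compound 3 (0.33 log units; beyond the scatter) and an at least 2.1-fold higher number from compound 1 to compound 2 (0.33 log units; beyond the scatter), each carrying the number from a measured value up to the limit. The remaining step, a step that the two limits leave unreadable from compound 2 to compound 3, connects two limits and gives no size. Among the measured compounds shown here, no measured step places a nitro on this ring, so the expectation for compound 4 rests on the shared starting point alone. In this assay compound 4 is expected to show a step that the limit leaves unreadable from compound 3 to compound 4, that is, to stay at or near the limit. Compound 4 is accordingly estimated at 40000 nM, within a range from 12000 nM to 120000 nM.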

Compound 4, half-maximal inhibitory concentration: > 31600 nM
Compound 4 ended at the assay's limit; the forecaster's own chance of this, stated with the estimate: 65%; the middle value is on the limit's open side.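

In this assay, nitro on this aromatic carbon gives an at least 2.1-fold higher number from compound 1 to compound 4 (0.33 log units; beyond the scatter), so the shift seen with methyl and trifluoromethyl also holds for a third group at this position. Compound 4 gives > 31600 nM, which is a limit of the assay and not a number. The steps that join compound 2, compound 3 and compound 4 cannot be read, so these three stay unranked, and the series now gathers at one end: the limit of > 31600 nM in this assay, at which 3 of the 4 values shown sit.

The compounds shown leave open how far past the limit any of the three substituted compounds lies, and so whether nitro differs from methyl or trifluoromethyl at all. They also leave open whether an amine, a carboxylic acid or a methoxy group at this position would keep the number measurable, as the unsubstituted compound 1 does at 14500 nM.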